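This account rests on a few compounds, and the source may have more. Where it says the series, first, only, none or still open, it means among the compounds named here.

Compound 1 `Cn1c(=O)c(S(=O)(=O)Cc2ccc(F)cc2)cc2cnc(Nc3ccc4[nH]ccc4c3)nc21`: 30000 nM
Compound 2 `Cn1c(=O)c(S(=O)(=O)c2ccc(F)cc2F)cc2cnc(Nc3ccc4[nH]ncc4c3)nc21`: 50000 nM

Both compounds were tested in a functional assay on K562 cells (Homo sapiens) for inhibition, read by trypan blue exclusion, with a stated time of 72 h; on this read-out lower numbers stand for stronger inhibition and higher numbers for weaker inhibition. Compound 1 has the lower of the two numbers, but the gap to compound 2 lies within the scatter, so the two compounds cannot be told apart on these data. The next compound is compound 3 `Cn1c(=O)c(S(=O)(=O)c2ccc(Br)cc2)cc2cnc(Nc3ccc4[nH]ccc4c3)nc21`, which has 4-bromophenyl in place of the 4-fluorobenzyl on the sulfonyl sulfur of compound 1: 4-bromophenyl in place of 4-fluorobenzyl on a sulfonyl sulfur. For the measured compounds named here, no measured pair shows the effect of a single change, so the data offer no direct guide to this one. In this assay, a modest step toward a lower number is expected, one not clearly beyond the scatter. The expected change is a 2.0-fold lower number from compound 1 to compound 3 (0.30 log units; within the scatter). For compound 3 the estimate is 15000 nM, with an expected range from 2000 nM to 60000 nM.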

Compound 3, half-maximal inhibitory concentration: 5000 nM
Estimate against measurement, compound 3: 3.0-fold (0.48 log units) above, and the stated range covers the measured number.
By their numbers in this assay, from the lowest: compound 3; then compounds 1 and 2 (each within the scatter of the next).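

In this assay, for the compounds shown here, the group on the sulfonyl sulfur matters: placing 4-bromophenyl there in place of 4-fluorobenzyl gives a 6.0-fold lower number from compound 1 to compound 3 (0.78 log units; beyond the scatter) as the one change that can be read on its own. That single swap exchanges the fluorine for a bromine and also gives up the benzyl carbon, so the step does not separate the two. Nothing at hand accounts for the step.

Left open is which of the two alterations carries the difference, a question that 4-fluorophenyl or 4-bromobenzyl on the same sulfonyl sulfur would address. Also open, as far as these compounds go, is how this position would respond to a different kind of group, such as an amine or a carboxylic acid on the phenyl ring, or a longer chain to the ring.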